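Chloro to methoxy on the aryl ring: expected effect

This account rests on a few compounds, and the source may have more. Where it says the series, first, only, none or still open, it means among the compounds named here.

Measured compounds:
- Compound 1, `O=C(/C=C/c1cccc(Cl)c1)c1ccc[nH]1`: 16000 nM
- Compound 2, `O=C(/C=C/c1ccc(Br)cc1)c1ccc[nH]1`: > 20000 nM

Among the compounds with values here, in an assay for inhibition of cytochrome P450 1A1 (Homo sapiens), read by fluorescence, using microsomes, with a stated time of 10 min (a lower number here means a stronger inhibitor, a higher number a weaker inhibitor), compound 1 gives 16000 nM, and this is the only actual number available. For compound 2 the result is a limit of the assay and not a number, (the limit of > 20000 nM in this assay, at which 1 of the 2 values shown sits). Within the data shown here, compound 1 therefore stands as the one compound with a measured potency, and that potency is weak.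

Compound 3, `COc1cccc(/C=C/C(=O)c2ccc[nH]2)c1`, has not yet been measured in this assay. It differs from compound 1 in one place: methoxy in place of chloro on an aromatic carbon. Among the measured compounds shown here, no measured pair of compounds shows what such a swap does here, so the size and direction of the step must be guessed.

With nothing in the measured values pointing either way, the expected step from compound 1 to compound 3 is estimated as small, a 1.1-fold lower number from compound 1 to compound 3 (0.03 log units; within the scatter), probably within the usual scatter. Compound 3 is therefore expected to give about 15000 nM, in an estimated range from 5000 nM to 40000 nM.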

Compound 3, half-maximal inhibitory concentration: 6200 nM
Estimate against measurement, compound 3: 2.4-fold (0.38 log units) above; measured number inside the range.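

In this assay, within the data shown here, the swap of chloro for methoxy gives the first measured change at this aromatic carbon: a 2.6-fold lower number from compound 1 to compound 3 (0.41 log units; beyond the scatter), a modest step. It shows that the group on this carbon can shift the reading, with methoxy, which brings two heavy atoms and one hydrogen-bond acceptor, giving a stronger inhibitor than chloro, although compound 3 at 6200 nM is still a weak one in absolute terms. A single pair cannot separate the added atoms from the added acceptor or from any other difference between the two groups, and nothing measured here bears on the cause of the step.

Going by these compounds, whether the trend would continue with an ethoxy group, a hydroxyl group or an amine on the same carbon remains open, as does what methoxy would do on another carbon of this ring. Compound 2 cannot settle the second question, since its > 20000 nM is a limit of the assay and not a number, and it differs from compound 1 in more than one place.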